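Shrinking the Ring on the Core Nitrogen

The source may report more compounds than this note shows. Statements on the series, on what has been measured and on what is new or still open speak of the compounds shown alone.

Three compounds have been measured so far in an assay on HEK-293T cells for antagonist activity at vitamin D3 receptor (Homo sapiens), read by a luciferase reporter, with a stated time of 24 h; a lower number here means a stronger inhibitor, a higher number a weaker inhibitor:
compound 1 `CCC(CC)n1c(-c2ccc(OCc3c(-c4c(Cl)cccc4Cl)noc3C(C)C)cc2)nc2ccc(C(=O)O)cc21` with 5690 nM;
compound 2 `CCCn1c(-c2ccc(OCc3c(-c4c(Cl)cccc4Cl)noc3C(C)C)cc2)nc2ccc(C(=O)O)cc21` with 1400 nM;
compound 3 `CC(C)c1onc(-c2c(Cl)cccc2Cl)c1COc1ccc(-c2nc3ccc(C(=O)O)cc3n2CC2CCCCC2)cc1` with 346 nM.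

Compound 3 stands at the lowest number of the three, and its steps to the other two lie beyond the scatter, so it is the strongest inhibitor in this assay among them. All three share one core and differ only in the group carried on an aromatic nitrogen. Moving from compound 1 to compound 2 trims a branched chain to a straight one, and the number falls a 4.1-fold lower number from compound 1 to compound 2 (0.61 log units; beyond the scatter). Moving from compound 2 to compound 3 adds a saturated ring at the end of that chain, and the number falls again a 4.0-fold lower number from compound 2 to compound 3 (0.61 log units; beyond the scatter). Taken together, the step is a 16-fold lower number from compound 1 to compound 3 (1.22 log units; beyond the scatter).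

Compound 4 `CC(C)c1onc(-c2c(Cl)cccc2Cl)c1COc1ccc(-c2nc3ccc(C(=O)O)cc3n2C2CCC2)cc1` makes a new change: cyclobutyl in place of cyclohexylmethyl on an aromatic nitrogen. The ring is now smaller and sits directly on the nitrogen, so the attaching carbon is branched as in compound 1, which gave the weakest result. The measured steps therefore point to a weaker inhibitor, and the expected step is a 4.3-fold higher number from compound 3 to compound 4 (0.64 log units; beyond the scatter). Compound 4 is estimated at 1500 nM, within a range from 400 nM to 6000 nM.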

Compound 4, half-maximal inhibitory concentration: 1100 nM
The estimate for compound 4 lay 1.4-fold (0.13 log units) above the measured number; measured number inside the range.
By their numbers in this assay, from the lowest: compound 3; then compounds 4 and 2 (each within the scatter of the next); then compound 1.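

Cyclobutyl gives back part of what cyclohexylmethyl gained (a 3.2-fold higher number from compound 3 to compound 4 (0.50 log units; beyond the scatter)), yet it still improves on pentan-3-yl (a 5.2-fold lower number from compound 1 to compound 4 (0.71 log units; beyond the scatter)), so a branched carbon on the aromatic nitrogen does not by itself bring the number up to that of compound 1. Compared with the open propyl chain, the ring shows no difference that can be separated from the scatter (a 1.3-fold lower number from compound 2 to compound 4 (0.10 log units; within the scatter)), so cyclobutyl and propyl cannot be ranked at this position. Having a ring is therefore not enough to lower the number, and among these four groups, only cyclohexylmethyl stands apart from all the others.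

Nothing available here explains why these groups rank as they do. Also open, as far as these compounds go, is whether ring size or the connecting carbon matters more: cyclobutylmethyl would keep that carbon with the smaller ring, while cyclohexyl would place the larger ring directly on the nitrogen, and each would test one of these changes on its own.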